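Alkyne to Alkene on a Nucleoside Core

The compounds below may be only part of what the source reports. "The series", "measured", "known", "first", "only" and "open" are said of these compounds alone.

Within the data shown here, compound 2 `OC[C@H]1OC(n2cnc3c(C#Cc4ccccc4)ncnc32)[C@H](O)[C@@H]1O` gives 0.2 ug/mL in a functional assay on K562 cells (Homo sapiens) for inhibition, read by thymidine incorporation, with a stated time of 5 h (on this read-out higher numbers stand for weaker inhibition and lower numbers for stronger inhibition), the lowest of the two numbers measured so far; compound 1 `Clc1nc2c(C#Cc3ccccc3)ncnc2n1C1CCOCC1` stands at a markedly higher number in this assay, where compound 1 gives 7 ug/mL, a gap beyond the scatter. Compound 3 `OC[C@H]1OC(n2cnc3c(/C=C/c4ccccc4)ncnc32)[C@H](O)[C@@H]1O` differs from compound 2 in one place: 2-phenylethenyl in place of 2-phenylethynyl on an aromatic carbon. Among the measured compounds shown here, no step between measured compounds shows the effect of this change. For compound 3 the step of a 2.5-fold higher number from compound 2 to compound 3 (0.40 log units; beyond the scatter) is expected to be small, toward a modestly higher number, and may sit within the scatter. Compound 3 is thus estimated at 0.5 ug/mL, with a range of 0.1 ug/mL to 3 ug/mL.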

Compound 3, half-maximal inhibitory concentration: 10 ug/mL
Compound 3: the middle estimate sits 20-fold (1.30 log units) below what was measured; the whole stated range lies below it.
By their numbers in this assay, from the lowest: compound 2; then compounds 1 and 3 (each within the scatter of the next).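

In this assay, the change from 2-phenylethynyl to 2-phenylethenyl on this aromatic carbon gives a 50-fold higher number from compound 2 to compound 3 (1.70 log units; beyond the scatter) and so costs much of the inhibition. The position is therefore far less tolerant than the matched counts of the two groups might suggest: the same heavy atoms and aromatic ring are present, and only a triple bond gives way to a double bond. Nothing at hand explains the step.

As far as these compounds go, it remains open whether a saturated phenylethyl chain or an amine at this carbon would retain inhibition. The same change on the core of compound 1 is also untested here.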